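Extending the ethoxy chain of compound 3 toward a chlorophenoxy group

A few compounds are considered here, and "the series" means these few. Any claim that something is new, unique, unknown or untested is made for them only; others in the source may bear on it.

Measured compounds in a functional assay on PANC-1 cells (Homo sapiens) for inhibition, read by MTT assay, with a stated time of 24 h, tested at 10 uM; on this read-out lower numbers stand for less inhibition and higher numbers for more inhibition at the one concentration tested (going by the name of the read-out):
compound 1 `CCOc1cc(=O)n(CCCO)c2c1CC(CC=C(C)C)C(C)(C)C2`, 66.5%
compound 2 `CC(C)=CCC1Cc2c(OC(=O)Nc3ccc(F)c(F)c3)cc(=O)n(CCCO)c2CC1(C)C`, 76.7%
compound 3 `CCOc1cc(=O)n(CCCO)c2c1CC(C/C=C(\C)CCC=C(C)C)C(C)(C)C2`, 67.8%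

Compound 3 stands second highest of the three numbers; its nearest neighbour is compound 1, and compound 2 lies furthest away, yet both gaps are within the scatter. Compound 4 `CC(C)=CCC/C(C)=C/CC1Cc2c(OCCCOc3ccc(Cl)cc3)cc(=O)n(CCCO)c2CC1(C)C` differs from compound 3 by (4-chlorophenoxy)methyl in place of hydrogen on a saturated chain carbon, two bonds along the chain from an oxygen on an aromatic ring, so the ethoxy becomes a 3-(4-chlorophenoxy)propoxy. Going by the values given here, no measured step makes this exact change. The closest are a number 10.2 percentage points higher from compound 1 to compound 2 (beyond the scatter), which altered the group on the aromatic oxygen, and a number 1.3 percentage points higher from compound 1 to compound 3 (within the scatter), a chain extension. The chain extension stayed within the scatter and the oxygen change was modest. Compound 4 is therefore expected to move by about a number 2.2 percentage points higher from compound 3 to compound 4 (within the scatter), a step not clearly beyond the scatter. The estimate for compound 4 is 70%, between 58% and 82%.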

Compound 4, a percentage reported as inhibition, at one concentration (the size of the read-out at that concentration, not a potency): 25.2%
Compound 4: middle estimate off by 44.8 percentage points, on the high side; the whole stated range lies above it.
By their numbers in this assay, from the lowest: compound 4; then compounds 1, 3 and 2 (each within the scatter of the next, the first and the last beyond it).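

Replacing ethoxy with 3-(4-chlorophenoxy)propoxy gives a number 42.6 percentage points lower from compound 3 to compound 4 (beyond the scatter) in this assay and so shows that a change on this aromatic oxygen can sharply lower the number, whereas the earlier change there gave a number 10.2 percentage points higher from compound 1 to compound 2 (beyond the scatter) and raised it. The size of the result therefore depends strongly on the group placed on this oxygen. Nothing available here explains the drop.

From the compounds shown here alone, it remains open whether the drop follows from the chlorine, the phenoxy ring or the propoxy chain length. A propoxy chain ending in an amine or a carboxylic acid could separate these possibilities.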